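Halogen and methoxy variants on the shared core

This account rests on a few compounds, and the source may have more. Where it says the series, first, only, none or still open, it means among the compounds named here.

compound 1 `O=c1c2ccccc2[se]n1-c1nnc(-c2ccc(Br)cc2)s1` — in a functional assay on A549 cells (Homo sapiens) for antiproliferative activity, read by CCK-8 assay, with a stated time of 48 h (on this read-out lower numbers stand for stronger inhibition and higher numbers for weaker inhibition), compound 1 gives 39100 nM
compound 2 `O=c1c2ccccc2[se]n1-c1nnc(-c2ccc(Cl)cc2)s1` — compound 2 gives 10400 nM
compound 3 `COc1ccc(-c2nnc(-n3[se]c4ccccc4c3=O)s2)cc1` — compound 3 gives 5930 nM

Compound 3 holds the lowest number of the three; its gap to compound 2 lies within the scatter, so no order between those two is claimed, while compound 1 sits clearly higher (a 6.6-fold lower number from compound 1 to compound 3 (0.82 log units; beyond the scatter)). Compound 4 `O=c1c2ccccc2[se]n1-c1nnc(-c2ccc(F)cc2)s1` differs from compound 3 by fluoro in place of methoxy on an aromatic carbon. Within the data shown here, no measured step swaps methoxy for fluoro; the steps that bear on it are a 3.8-fold lower number from compound 1 to compound 2 (0.58 log units; beyond the scatter) and a 1.8-fold lower number from compound 2 to compound 3 (0.24 log units; within the scatter), both replacements at the same carbon, each giving a modest drop or a change within the scatter. For compound 4 the step of a 1.2-fold higher number from compound 3 to compound 4 (0.07 log units; within the scatter) is therefore expected to stay within the scatter. Compound 4 is estimated at 7000 nM, range 2500 nM to 20000 nM.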

Compound 4, half-maximal inhibitory concentration: 21100 nM
Compound 4: middle estimate off by 3.0-fold (0.48 log units), on the low side; the whole stated range lies below it.
By their numbers in this assay, from the lowest: compounds 3 and 2 (each within the scatter of the next); then compounds 4 and 1 (each within the scatter of the next).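

At this aromatic carbon, fluoro does not join the lower pair: a 3.6-fold higher number from compound 3 to compound 4 (0.55 log units; beyond the scatter) and a 2.0-fold higher number from compound 2 to compound 4 (0.31 log units; beyond the scatter) in this assay both lie beyond the scatter, while a 1.9-fold lower number from compound 1 to compound 4 (0.27 log units; within the scatter) stays within it. Among the halogens the numbers therefore do not run stepwise from bromo through chloro to fluoro, with chloro compound 2 lower than both compound 1 and compound 4. Nothing at hand accounts for this order.

On these data alone, whether an amine, a carboxylic acid or a longer alkoxy chain at this carbon would give a number lower than that of compound 3 remains open.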